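The source may report more compounds than this note shows. Statements on the series, on what has been measured and on what is new or still open speak of the compounds shown alone.

In a functional assay on HepG2 cells (Homo sapiens) for inhibition, read by MTT assay, with a stated time of 72 h (on this read-out higher numbers stand for weaker inhibition and lower numbers for stronger inhibition), compound 3 `O=C(Nc1cccc(OCc2cn(-c3ccccc3C(F)(F)F)nn2)c1)Nc1ccc(Cl)c(C(F)(F)F)c1` gives 2320 nM, the second highest of the three numbers in hand. Its nearest neighbour is compound 2 `O=C(Nc1cccc(OCc2cn(-c3ccccc3F)nn2)c1)Nc1ccc(Cl)c(C(F)(F)F)c1`, which gives 1520 nM; the step of a 1.5-fold higher number from compound 2 to compound 3 (0.18 log units; within the scatter) stays within the scatter. Compound 1 `CCc1cccc(-n2cc(COc3cccc(NC(=O)Nc4ccc(Cl)c(C(F)(F)F)c4)c3)nn2)c1` gives 37900 nM and lies furthest off, with a 16-fold lower number from compound 1 to compound 3 (1.21 log units; beyond the scatter) and a 25-fold lower number from compound 1 to compound 2 (1.40 log units; beyond the scatter) both beyond the scatter. Compound 4 `COc1ccccc1-n1cc(COc2cccc(NC(=O)Nc3ccc(Cl)c(C(F)(F)F)c3)c2)nn1` differs from compound 3 by methoxy in place of trifluoromethyl on an aromatic carbon. Going by the values given here, the only measured step at this place is a 1.5-fold higher number from compound 2 to compound 3 (0.18 log units; within the scatter), a swap of one small group for another that left the number unchanged within the scatter; no measured compound carries a methoxy at that place. The expected step in this assay is therefore small, a 1.1-fold lower number from compound 3 to compound 4 (0.02 log units; within the scatter), in no firm direction. Compound 4 is expected to give 2200 nM, between 800 nM and 7000 nM.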

Compound 4, half-maximal inhibitory concentration: 11300 nM
Beside the measured number, compound 4's estimate is 5.1-fold (0.71 log units) below it; measured number outside the range, above it.
By their numbers in this assay, from the lowest: compounds 2 and 3 (each within the scatter of the next); then compound 4; then compound 1.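

In this assay, this aromatic carbon does respond to the choice of small group: methoxy brings a 4.9-fold higher number from compound 3 to compound 4 (0.69 log units; beyond the scatter) and a 7.4-fold higher number from compound 2 to compound 4 (0.87 log units; beyond the scatter), although fluoro and trifluoromethyl remain within the scatter of each other. The 2-methoxyphenyl group still keeps part of the gain over 3-ethylphenyl, with a 3.4-fold lower number from compound 1 to compound 4 (0.53 log units; beyond the scatter) in this series. Nothing available explains why methoxy separates from the other two groups.

From the compounds shown here alone, whether a hydroxyl, an amine or ethoxy on this aromatic carbon would track compound 4 or compounds 2 and 3 remains open.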